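A few compounds are considered here, and "the series" means these few. Any claim that something is new, unique, unknown or untested is made for them only; others in the source may bear on it.

Measured so far in a functional assay on the whole organism with Mus musculus as the target; on this read-out lower numbers stand for an effect already at smaller amounts and higher numbers for an effect only at larger amounts of compound:
compound 1 `CCN(C)C(=O)/C=C1\CCc2c(F)cc(F)cc21` gives 56 mg/kg
compound 2 `CNC(=O)/C=C1\CCc2c(F)cc(F)cc21` gives 45 mg/kg
compound 3 `NC(=O)/C=C1\CCc2c(F)cc(F)cc21` gives 69 mg/kg

Compound 1 stands within the scatter of both other compounds: a 1.2-fold lower number from compound 1 to compound 2 (0.09 log units; within the scatter) and a 1.2-fold higher number from compound 1 to compound 3 (0.09 log units; within the scatter). Compound 4 `CCN(C)C(=O)/C=C1\CCc2ccc(F)cc21` differs from it by hydrogen in place of fluoro on an aromatic carbon, with hydrogen in place of fluoro on an aromatic carbon, ortho to a fused ring and meta to the remaining fluoro group. Going by the values given here, no measured step touches that carbon. The measured steps all lie on the amide-type nitrogen, and the third, a 1.5-fold higher number from compound 2 to compound 3 (0.19 log units; within the scatter), also stays within the scatter. They bear only indirectly, so no step beyond the scatter is expected in this assay, and no direction is favoured. The estimated step is a 1.1-fold higher number from compound 1 to compound 4 (0.03 log units; within the scatter). For compound 4 the expected value is 60 mg/kg, with an expected range from 27 mg/kg to 130 mg/kg.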

Compound 4, dose for half-maximal effect: 100 mg/kg
Estimate against measurement, compound 4: 1.7-fold (0.22 log units) below; low and high end bracket the measured number.
By their numbers in this assay, from the lowest: compounds 2, 1, 3 and 4 (each within the scatter of the next, the first and the last beyond it).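

Going by these compounds alone, compound 4 gives the first reading on the aromatic carbon ortho to a fused ring, as the earlier steps all lie on the amide side. In this assay, hydrogen in place of fluoro there stays within the scatter (a 1.8-fold higher number from compound 1 to compound 4 (0.25 log units; within the scatter)), so this fluoro is not shown to matter on this read-out, though the single step allows only a cautious reading. No supporting data bear on this result.

Still open, from the compounds shown here alone, is how chloro or methoxy would read at this carbon. Also open, going by these compounds, is whether the remaining fluoro group can give way to hydrogen, and whether the same change reads alike on the amides of compound 2 and compound 3.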